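Two weak antagonists and a ring-nitrogen swap

The source may hold more compounds than are shown below. What is called first, only, known or untested is meant among the compounds shown, and "the series" means these compounds.

The series holds two measured compounds. Compound 1 `CC1CC(=O)N(c2ccccc2C(=O)OCC2CCCN(CCCCCc3ccccc3)C2)C1=O` and compound 2 `O=C(Nc1ccccn1)c1ccccc1-c1ccccc1` were tested in an in vitro functional assay on HEK ts201 cells for antagonist activity at Neuronal acetylcholine receptor; alpha3/beta4 (Homo sapiens), read by fluorescence and calcium flux; a higher number here means a weaker inhibitor, a lower number a stronger inhibitor. Compound 1 gives 4170 nM. Compound 2 gives 17500 nM, which is the highest of the two numbers in this assay; the gap to compound 1 lies beyond the usual scatter, so compound 2 is the weaker inhibitor of the pair. The two compounds share no single-point difference, and nothing further can be read from their comparison.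

Compound 3 `O=C(Nc1ccncn1)c1ccccc1-c1ccccc1` has not yet been measured. It differs from compound 2 in one place: pyrimidin-4-yl in place of pyridin-2-yl on an amide-type nitrogen. The change keeps the amide and the rest of the core of compound 2 untouched and is confined to the ring on the amide-type nitrogen, pyrimidin-4-yl in place of pyridin-2-yl.

Within the data shown here, no measured pair shows what this exchange does, so the expectation rests on compound 2 alone. The step of a 1.0-fold lower number from compound 2 to compound 3 (0.01 log units; within the scatter) is expected to stay within the scatter, with no clear direction. Compound 3 is therefore estimated at 17000 nM in this assay, within a range of 7000 nM to 45000 nM.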

Compound 3, half-maximal inhibitory concentration: 39600 nM
The estimate for compound 3 lay 2.3-fold (0.37 log units) below the measured number; low and high end bracket the measured number.
By their numbers in this assay, from the lowest: compound 1; then compound 2; then compound 3.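

Pyrimidin-4-yl in place of pyridin-2-yl on the amide-type nitrogen is the only single-point change in the series that can be read so far, and in this assay it gives a 2.3-fold higher number from compound 2 to compound 3 (0.35 log units; beyond the scatter) as a modest loss of inhibition beyond the scatter. This position is therefore not indifferent to the ring it carries: with the ring size and heavy-atom count unchanged, the exchange of one ring carbon for a second ring nitrogen weakens inhibition in this one pair. Nothing measured on these compounds accounts for the step, which stands as an observation without an explanation.

On these data alone, whether the loss follows from the added ring nitrogen itself or from where that nitrogen stands in the ring remains open, as a single pair does not separate the two, and pyrimidin-2-yl, pyrazin-2-yl or a plain phenyl on the same nitrogen would bear on that question. Also open, as far as these compounds go, is how an amine or a carboxylic acid on the pyridin-2-yl ring would act on inhibition.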